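Cytotoxicity of Pyrimidine Analogues: Estimating a Fluorophenyl Variant

The source may hold more compounds than are shown below. What is called first, only, known or untested is meant among the compounds shown, and "the series" means these compounds.

Measured compounds:
- Compound 1, `Cc1cc(C)cc(-c2cnc(Nc3ccc(C#N)cc3)nc2Oc2c(C)cc(C#N)cc2C)c1`: 39000 nM
- Compound 2, `Cc1cc(C#N)cc(C)c1Oc1nc(Nc2ccc(C#N)cc2)ncc1-c1ccoc1`: 4980 nM
- Compound 3, `Cc1cc(C#N)cc(C)c1Oc1nc(Nc2ccc(C#N)cc2)ncc1-c1cccs1`: 6430 nM

The read-out is an ADME assay on MT4 cells (Homo sapiens) for cytotoxicity, read by MTT assay, with a stated time of 5 days; on this read-out higher numbers stand for lower toxicity in this test and lower numbers for higher toxicity in this test. On these three numbers compound 3 stands second highest; its nearest neighbour is compound 2, and the step of a 1.3-fold higher number from compound 2 to compound 3 (0.11 log units; within the scatter) lies within the scatter, so the two cannot be told apart. Compound 1 stands furthest away, with a 6.1-fold lower number from compound 1 to compound 3 (0.78 log units; beyond the scatter).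

Compound 4, `Cc1cc(C#N)cc(C)c1Oc1nc(Nc2ccc(C#N)cc2)ncc1-c1ccc(F)cc1`, is not yet measured. It differs from compound 3 in one place: 4-fluorophenyl in place of thiophen-2-yl on an aromatic carbon.

Within the data shown here, two measured steps bear on this change. Both a 7.8-fold lower number from compound 1 to compound 2 (0.89 log units; beyond the scatter) and a 6.1-fold lower number from compound 1 to compound 3 (0.78 log units; beyond the scatter) show that exchanging one six-membered aromatic ring of carbon only for a five-membered aromatic ring with one hetero atom gave a modest fall in the number. Among the measured compounds shown here, compound 4 reverses that kind of exchange, bringing back a six-membered aromatic ring of carbon only, though with a fluorine rather than two methyl groups; no measured step tests that difference directly. A modest rise in this assay is therefore expected, a 3.1-fold higher number from compound 3 to compound 4 (0.49 log units; beyond the scatter), and compound 4 is estimated at 20000 nM, within 6000 nM to 50000 nM.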

Compound 4, half-maximal cytotoxic concentration: 42700 nM
For compound 4 the middle estimate is 2.1-fold (0.33 log units) below the measured one; low and high end bracket the measured number.
By their numbers in this assay, from the lowest: compounds 2 and 3 (each within the scatter of the next); then compounds 1 and 4 (each within the scatter of the next).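

In this assay, 4-fluorophenyl at this position separates clearly from both five-membered rings, with a 6.6-fold higher number from compound 3 to compound 4 (0.82 log units; beyond the scatter) and with an 8.6-fold higher number from compound 2 to compound 4 (0.93 log units; beyond the scatter) as well. Against 3,5-dimethylphenyl it cannot be told apart (see a 1.1-fold higher number from compound 1 to compound 4 (0.04 log units; within the scatter)), so across these four compounds the two six-membered rings of carbon only stand together above the two five-membered rings, and no compound goes against that split. No measurement on hand explains this split.

The compounds shown leave open whether the split follows ring size or the carbon-only make-up of the ring, which a pyridine ring, six-membered but with a ring nitrogen, would help to separate. They also leave open how a non-aromatic group at this position, such as an amine or a carboxylic acid, would behave.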